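Short half-lives across a cyclopentyl amide urea series

This account rests on a few compounds, and the source may have more. Where it says the series, first, only, none or still open, it means among the compounds named here.

The series shares one urea core, varied at the aryl group and at the acyl group on the ring nitrogen. Compound 1 `CCc1ccc(NC(=O)N2CCCN(C(=O)CCC3CCCC3)CC2)cc1`, compound 2 `CC(C)(C)c1ccc(NC(=O)N2CCCN(C(=O)CCC3CCCC3)CC2)cc1` and compound 3 `CC(C)(C)c1ccc(NC(=O)N2CCCN(C(=O)CC3CCCC3)CC2)cc1` have all been run in an in vitro ADME assay on microsomes from liver (Homo sapiens) for metabolic stability, read by LC-MS; on this read-out lower numbers stand for a shorter-lived compound and higher numbers for a longer-lived compound. Compound 1 gives 0.0833 h, compound 2 gives 0.05 h and compound 3 gives 0.05 h. The step of a 1.7-fold lower number from compound 1 to compound 2 (0.22 log units; within the scatter) and the step of no change at the digits printed from compound 2 to compound 3 (within the scatter) both stay inside the scatter, so compound 3 stands level with compound 2 and is not separated from compound 1 either.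

Compound 4 `CC(C)(C)c1ccc(NC(=O)N2CCCN(C(=O)C3CCCCC3)CC2)cc1` differs from compound 3 by cyclohexyl in place of cyclopentylmethyl on a carbonyl carbon. For the measured compounds named here, the only measured step at the same place, no change at the digits printed from compound 2 to compound 3 (within the scatter), gave no change, and the aryl change a 1.7-fold lower number from compound 1 to compound 2 (0.22 log units; within the scatter) was also flat. With all three numbers within scatter of each other, no movement beyond the scatter is expected in this assay: the expected step is no change at the digits printed from compound 3 to compound 4 (within the scatter). Compound 4 is therefore estimated at 0.05 h, with a range from 0.025 h to 0.1 h.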

Compound 4, half-life: 0.0667 h
For compound 4 the middle estimate is 1.3-fold (0.13 log units) below the measured one, within the range that was stated.
By their numbers in this assay, from the lowest: compounds 2, 3, 4 and 1 (each within the scatter of the next).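

Putting cyclohexyl on the carbonyl carbon, with the same atoms joined differently, gives a 1.3-fold higher number from compound 3 to compound 4 (0.13 log units; within the scatter) in this assay, and the exchange for 2-cyclopentylethyl gives a 1.3-fold higher number from compound 2 to compound 4 (0.13 log units; within the scatter). The earlier step at this place kept the five-membered ring and altered only the chain to it, whereas these steps also replace it with a six-membered non-aromatic ring of carbon only bound directly to the carbonyl carbon, and both stay within the scatter. Nothing available explains why these half-lives lie so close together.

Open, as far as these compounds go, is whether a group carrying a heteroatom on the carbonyl carbon, such as a tetrahydropyranyl ring or a carboxylic acid, would give a step beyond the scatter. Also open, from the compounds shown here alone, is whether trifluoromethyl in place of tert-butyl on the aromatic carbon would do so.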